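Adding a chlorine to the furan of compound 3

This account rests on a few compounds, and the source may have more. Where it says the series, first, only, none or still open, it means among the compounds named here.

Three compounds share one core. Compound 1 `Clc1ccc(-c2cc(-c3ccco3)nc(-c3cccs3)c2)o1` gives 18800 nM in a functional assay on HeLa cells (Homo sapiens) for cytotoxicity, in the presence of a further agent that is not named here; on this read-out higher numbers stand for weaker inhibition and lower numbers for stronger inhibition. Compound 2 `Clc1cccc(-c2cc(-c3ccc(Cl)o3)cc(-c3cccs3)n2)c1` gives 12800 nM in this assay. Compound 3 `Clc1ccc(-c2cc(-c3ccco3)cc(-c3cccs3)n2)cc1` gives 32700 nM in this assay, the highest number of the three; its gap to compound 1 is within the scatter, its gap to compound 2 is beyond it.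

Going by the values given here, the only measured step, a 1.5-fold lower number from compound 1 to compound 2 (0.17 log units; within the scatter), concerns a different change, 3-chlorophenyl in place of furan-2-yl on an aromatic carbon, and was within the scatter. Compound 4 `Clc1ccc(-c2cc(-c3ccc(Cl)o3)cc(-c3cccs3)n2)cc1` is to be measured in this assay. It differs from compound 3 by chloro in place of hydrogen on an aromatic carbon of a five-membered aromatic ring with one oxygen, next to the ring oxygen; read one bond further out, furan-2-yl becomes 5-chlorofuran-2-yl. No measured pair isolates this change, so the measured step gives no direct guidance; compound 2, which also carries 5-chlorofuran-2-yl, gives the lowest number shown.

Compound 4 is therefore expected to give 20000 nM in this assay, within a range from 8000 nM to 50000 nM. The expected step of a 1.6-fold lower number from compound 3 to compound 4 (0.21 log units; within the scatter) is small and not clearly beyond the scatter.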

Compound 4, half-maximal inhibitory concentration: 21300 nM
For compound 4 the middle estimate is 1.1-fold (0.03 log units) below the measured one; low and high end bracket the measured number.
By their numbers in this assay, from the lowest: compounds 2, 1, 4 and 3 (each within the scatter of the next, the first and the last beyond it).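

Going by these compounds alone, this is the only pair that isolates chloro in place of hydrogen on the furan carbon next to the ring oxygen, and in this assay that change gives a 1.5-fold lower number from compound 3 to compound 4 (0.19 log units; within the scatter), so on this core furan-2-yl and 5-chlorofuran-2-yl cannot be told apart. With 5-chlorofuran-2-yl held constant, the step with 4-chlorophenyl in place of 3-chlorophenyl, a 1.7-fold higher number from compound 2 to compound 4 (0.22 log units; within the scatter), also stays inside the usual spread of repeat measurements. The same holds for 4-chlorophenyl in place of furan-2-yl, a 1.1-fold higher number from compound 1 to compound 4 (0.05 log units; within the scatter), so compound 4 cannot be separated from any of the three earlier compounds.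

No evidence on the cause of these small steps is available here. From the compounds shown here alone, it remains open whether a different group on this same furan carbon, such as an amine, a carboxylic acid or a longer chain, would shift the number beyond that spread, or whether this position has little bearing on the read-out.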